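The source may hold more compounds than are shown below. What is called first, only, known or untested is meant among the compounds shown, and "the series" means these compounds.

The series shares a single core, seen in compound 1 `CC(C)c1c(C(=O)NCc2ccccc2)nn(-c2ccc(F)cc2)c1OC[C@@H](O)C[C@@H](O)CC(=O)O`, in which the amide nitrogen carries an unsubstituted benzyl group. In a functional assay on L6 cells (Rattus norvegicus) for inhibition (a higher number here means a weaker inhibitor, a lower number a stronger inhibitor), compound 1 gives 880 nM. Compound 2 `Cc1ccc(CNC(=O)c2nn(-c3ccc(F)cc3)c(OC[C@@H](O)C[C@@H](O)CC(=O)O)c2C(C)C)cc1` carries a methyl on the benzyl ring, and in this assay compound 2 gives 2110 nM, the highest of the two numbers recorded; the step of a 2.4-fold higher number from compound 1 to compound 2 (0.38 log units; beyond the scatter) is modest but beyond the scatter. Compound 3 `CC(C)c1c(C(=O)N(C)Cc2cccc(C(F)(F)F)c2)nn(-c2ccc(F)cc2)c1OC[C@@H](O)C[C@@H](O)CC(=O)O`, which carries a methyl on the amide nitrogen together with a trifluoromethyl-substituted benzyl, has no result reported in this assay, where compound 3 stands at "not determined" (no result reported), so the effect of methylating the amide nitrogen is not documented anywhere in the set.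

Compound 4 `CC(C)c1c(C(=O)N(C)Cc2ccc(F)c(F)c2)nn(-c2ccc(F)cc2)c1OC[C@@H](O)C[C@@H](O)CC(=O)O` differs from compound 2 by (3,4-difluorobenzyl)(methyl)amino in place of (4-methylbenzyl)amino on a carbonyl carbon. Among the compounds with values here, no measured step covers either the two fluorines or the methyl on the nitrogen; the only step available, from compound 1 to compound 2, concerns a methyl on the benzyl ring that compound 4 lacks. With so little to lean on, compound 4 is expected to land close to compound 2, the step of a 1.4-fold lower number from compound 2 to compound 4 (0.15 log units; within the scatter) being expected to fall within or near the scatter. Compound 4 is therefore estimated at 1500 nM, with a broad range from 400 nM to 6000 nM.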

Compound 4, half-maximal inhibitory concentration: 4570 nM
Compound 4: middle estimate off by 3.0-fold (0.48 log units), on the low side; measured number inside the range.
By their numbers in this assay, from the lowest: compound 1; then compound 2; then compound 4.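

In this assay the change at the carbonyl carbon to (3,4-difluorobenzyl)(methyl)amino, which removes the amide hydrogen, gives a 2.2-fold higher number from compound 2 to compound 4 (0.34 log units; beyond the scatter) and, measured against the unsubstituted benzylamino group, a 5.2-fold higher number from compound 1 to compound 4 (0.72 log units; beyond the scatter) as well. This position therefore now has a reading for a group without a hydrogen-bond donor, and compound 4 has the highest number of the three compounds with a result. Nothing available accounts for this rise.

The compounds shown do not separate the contribution of the methyl on the nitrogen from that of the two fluorines, as each step changes them together and compound 3 has no number. Also open, going by these compounds, is how a morpholine amide or a pyridin-3-ylmethylamino group at this carbonyl carbon would compare.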